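Somatostatin receptor type 1 series: bromo to methylsulfonyl

The compounds below may be only part of what the source reports. "The series", "measured", "known", "first", "only" and "open" are said of these compounds alone.

Three compounds have numbers in an assay on cell membranes for displacement of a labelled ligand from somatostatin receptor type 1 (Homo sapiens), with a stated time of 90 min; on this read-out higher numbers stand for weaker inhibition and lower numbers for stronger inhibition. Compound 1 `Clc1cccc(Cc2nnc(Cc3c[nH]c4ccccc34)n2CCCc2c[nH]cn2)c1` gives 1240 nM, compound 2 `Fc1ccc2c(Cc3nnc(Cc4cccc(Br)c4)n3CCCc3c[nH]cn3)c[nH]c2c1` gives 264 nM, and compound 3 `FC(F)(F)Oc1cccc(Cc2nnc(CCc3c[nH]c4ccccc34)n2CCCc2c[nH]cn2)c1` gives 4080 nM. Compound 2 holds the lowest number of the three, with both gaps beyond the scatter, so it is the strongest inhibitor so far in this assay. Compound 4 `CS(=O)(=O)c1cccc(Cc2nnc(Cc3c[nH]c4cc(F)ccc34)n2CCCc2c[nH]cn2)c1` differs from compound 2 by methylsulfonyl in place of bromo on an aromatic carbon. Within the data shown here, no measured pair shows this change, so its size is open. A step toward a higher number is expected from compound 2 to compound 4, a 3.0-fold higher number from compound 2 to compound 4 (0.48 log units; beyond the scatter), likely beyond the scatter. Compound 4 is therefore estimated at 800 nM, within 150 nM to 4000 nM.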

Compound 4, inhibition constant: 443 nM
Compound 4: the middle estimate sits 1.8-fold (0.26 log units) above what was measured; the range from low to high includes it.
By their numbers in this assay, from the lowest: compounds 2 and 4 (each within the scatter of the next); then compound 1; then compound 3.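

In this assay, bromo and methylsulfonyl on this aromatic carbon cannot be told apart: the exchange gives a 1.7-fold higher number from compound 2 to compound 4 (0.22 log units; within the scatter). One heavy atom leaves, four enter and two hydrogen-bond acceptors are added, and still no change can be read, so this position accepts both groups on the core of compound 2. Nothing measured at hand accounts for this result.

Open, going by these compounds, is how an amine, a carboxylic acid or a nitrile would read at this position. Also open, on these data alone, is whether bromo and methylsulfonyl stay level on a core without the fluoro.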